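The compounds below may be only part of what the source reports. "The series", "measured", "known", "first", "only" and "open" are said of these compounds alone.

Values in an ADME assay on the whole organism (Mus musculus, strain CD-1) for pharmacokinetics, at a dose of 10 mg/kg by the oral route (on this read-out higher numbers stand for higher oral bioavailability and lower numbers for lower oral bioavailability), so far:
Compound 1 `COc1cc([C@](O)(CCN(C)C)[C@@H](c2cc3cc(Br)ccc3nc2OC)c2cccc(OC)c2F)cc(OC(C)C)n1` gives 43%
Compound 2 `COc1cc([C@](O)(CCN(C)C)[C@@H](c2cc3cc(Br)ccc3nc2OC)c2cccc(OC)c2F)cc(SC)n1` gives 31%

Compound 2 is the lower of the two, and the gap to compound 1 lies beyond the scatter. Compound 3 `COc1cccc([C@H](c2cc3cc(Br)ccc3nc2OC)[C@@](O)(CCN(C)C)c2cc(SC)nc(SC)c2)c1F` is the next case: methylsulfanyl in place of methoxy on an aromatic carbon (methylsulfanyl in place of methoxy on an aromatic carbon, next to the ring nitrogen). Among the compounds with values here, the one measured step that bears on it is the modest a number 12 percentage points lower from compound 1 to compound 2 (beyond the scatter) which also brought in methylsulfanyl, there in place of isopropoxy. On that precedent a smaller fall in this assay is expected, within the scatter (a number 8 percentage points lower from compound 2 to compound 3 (within the scatter)). The estimated value for compound 3 is 23% with an expected range (10% to 38%).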

Compound 3, oral bioavailability: 66%
Compound 3: the middle estimate sits 43 percentage points below what was measured; measured number above the stated range.
By their numbers in this assay, from the lowest: compound 2; then compound 1; then compound 3.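

In this assay, methylsulfanyl in place of methoxy, next to the ring nitrogen, brings a number 35 percentage points higher from compound 2 to compound 3 (beyond the scatter), so methylsulfanyl does not lower the number in every exchange shown. Replacing the whole substituted ring group gives a number 23 percentage points higher from compound 1 to compound 3 (beyond the scatter), placing the compound with two methylsulfanyl groups clear of the isopropoxy compound. Nothing available accounts for the rise. Open, on these data alone, is whether the rise is specific to methylsulfanyl at this position, or whether an amine or an ethylsulfanyl group there would give a similar number.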